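Working notes on the series ahead of compound 4

A few compounds are considered here, and "the series" means these few. Any claim that something is new, unique, unknown or untested is made for them only; others in the source may bear on it.

Measured so far:
compound 1 `O=C1C=COC(/C=C/c2ccccc2)C1` — 122 uM
compound 2 `O=C1C=COC(/C=C/c2ccc(C(F)(F)F)cc2)C1` — 38.6 uM
compound 3 `O=c1ccoc(/C=C/c2ccccc2)c1` — 285 uM

In a functional assay on U-251 cells (Homo sapiens) for inhibition, read by sulforhodamine B assay, with a stated time of 48 h (on this read-out higher numbers stand for weaker inhibition of growth and lower numbers for stronger inhibition of growth), compound 3 gives the highest of the three numbers; compound 1 sits nearest to it and compound 2 furthest from it, both gaps lying beyond the scatter. Compound 4 `COc1ccc(/C=C/c2cc(=O)cco2)cc1` differs from compound 3 in one place: methoxy in place of hydrogen on an aromatic carbon. Within the data shown here, no measured pair carries this exact change. Among the measured compounds shown here, the one step that bears on it is the substitution on the same aromatic carbon in the other core, a 3.2-fold lower number from compound 1 to compound 2 (0.50 log units; beyond the scatter), which shows that a group entering at this position can lower the number beyond the scatter. That step, however, introduced trifluoromethyl, not methoxy, and the core of compound 3 carries a conjugated ring where compound 1 does not, so the transfer is loose. A modest lowering is expected, smaller than that seen from compound 1 to compound 2 and possibly within the scatter: compound 4 is estimated at 170 uM (range 70 uM to 400 uM), an expected step of a 1.7-fold lower number from compound 3 to compound 4 (0.22 log units; within the scatter).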

Compound 4, concentration for growth inhibition (reported as GI): 278 uM
Beside the measured number, compound 4's estimate is 1.6-fold (0.21 log units) below it, within the range that was stated.
By their numbers in this assay, from the lowest: compound 2; then compound 1; then compounds 4 and 3 (each within the scatter of the next).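

In this assay, methoxy in place of hydrogen on an aromatic carbon, para to a group of 9 heavy atoms, leaves the number on the core of compound 3 within the scatter (a 1.0-fold lower number from compound 3 to compound 4 (0.01 log units; within the scatter)). A group entering at this place therefore does not by itself shift the read-out, which the earlier step with trifluoromethyl on the core of compound 1 (a 3.2-fold lower number from compound 1 to compound 2 (0.50 log units; beyond the scatter)) could not show; those two steps differ in both group and core, so neither difference can be singled out. Nothing available accounts for this outcome.

The compounds shown leave open whether trifluoromethyl would lower the number on the core of compound 3, and whether methoxy would do so on the core of compound 1. From the compounds shown here alone, how an amine or a carboxylic acid at the same carbon would read is also open.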